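The compounds below may be only part of what the source reports. "The series", "measured", "known", "first", "only" and "open" are said of these compounds alone.

Measured so far in an ADME assay on the whole organism (strain FVB) for pharmacokinetics, with Mus musculus as the target, read by LC-MS, at a dose of 30 mg/kg by the oral route; on this read-out higher numbers stand for higher exposure at the dose given and lower numbers for lower exposure:
- compound 1, `NCCOc1ccc([C@H]2CC[C@]3(CC2)OOC2(O3)C3CC4CC(C3)CC2C4)cc1`: 1370 ng.h/mL
- compound 2, `CC(C)(O)CNCCCOc1ccc([C@H]2CC[C@]3(CC2)OOC2(O3)C3CC4CC(C3)CC2C4)cc1`: 11100 ng.h/mL
- compound 3, `c1cc([C@H]2CC[C@]3(CC2)OOC2(O3)C3CC4CC(C3)CC2C4)ccc1OC1CCNCC1`: 7200 ng.h/mL

Compound 1 gives the lowest of the three numbers; its nearest neighbour is compound 3 and the furthest is compound 2, and both gaps lie beyond the scatter. The two changes made to compound 1 so far both raised exposure: an 8.1-fold higher number from compound 1 to compound 2 (0.91 log units; beyond the scatter) and a 5.3-fold higher number from compound 1 to compound 3 (0.72 log units; beyond the scatter), each a modest step. Compound 2 and compound 3 sit within the scatter of each other.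

Compound 4, `c1cc([C@H]2CC[C@]3(CC2)OOC2(O3)C3CC4CC(C3)CC2C4)ccc1OCC1CCNCC1`, is not yet measured. Against compound 1 the change is piperidin-4-yl in place of aminomethyl on a saturated chain carbon bound to an oxygen on an aromatic ring. Within the data shown here, the step from compound 1 to compound 3 is the closest precedent, since it also brings piperidin-4-yl onto the oxygen on the aromatic ring, only one saturated chain carbon shorter; the step to compound 2 shows that another reworking of the amine end of this chain gave a rise of similar size. On that basis a modest rise in this assay beyond the scatter is expected for compound 4, with a 4.0-fold higher number from compound 1 to compound 4 (0.60 log units; beyond the scatter). The estimate for compound 4 is 5500 ng.h/mL, with a range from 2000 ng.h/mL to 14000 ng.h/mL.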

Compound 4, area under the concentration-time curve: 4040 ng.h/mL
Estimate against measurement, compound 4: 1.4-fold (0.13 log units) above; low and high end bracket the measured number.
By their numbers in this assay, from the lowest: compound 1; then compounds 4, 3 and 2 (each within the scatter of the next, the first and the last beyond it).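

In this assay, the gain over the primary amine survives when piperidin-4-yl sits one saturated chain carbon further from the oxygen on an aromatic ring (a 2.9-fold higher number from compound 1 to compound 4 (0.47 log units; beyond the scatter)), and this added carbon gives no separation from the directly attached ring (a 1.8-fold lower number from compound 3 to compound 4 (0.25 log units; within the scatter)), a gap within the scatter. The open chain of compound 2 does stand clear of compound 4 (a 2.7-fold lower number from compound 2 to compound 4 (0.44 log units; beyond the scatter)), although compound 2 and compound 3 lie within the scatter of each other, so these results give no single order for the three amine ends that runs beyond the scatter at each step. No supporting data bear on the reason for these differences.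

Compound 2 changes both the chain length and the substituent on the nitrogen, leaving the share of its 2-hydroxy-2-methylpropyl group in the exposure unresolved. On these data alone, the effect of a methyl group on the piperidine nitrogen, of a morpholine ring in place of piperidine, or of a longer chain carrying the piperidine ring also remains open.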